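The source may hold more compounds than are shown below. What is called first, only, known or untested is meant among the compounds shown, and "the series" means these compounds.

Compound 1 `COc1cc2c(Oc3ccc(NC(=O)c4cn(-c5ccccc5)nn4)cc3F)ccnc2cc1OCCCN1CCCCC1` carries a plain phenyl on its triazole ring, and in a functional assay on NCI-H460 cells (Homo sapiens) for cytotoxicity, read by MTT assay, with a stated time of 72 h (on this read-out higher numbers stand for weaker inhibition and lower numbers for stronger inhibition), compound 1 gives 210 nM. Compound 2 `COc1cc2c(Oc3ccc(NC(=O)c4cn(-c5ccccc5C)nn4)cc3F)ccnc2cc1OCCCN1CCCCC1` differs from it by one change, (methyl in place of hydrogen on an aromatic carbon), which gave a 10-fold higher number from compound 1 to compound 2 (1.00 log units; beyond the scatter); in this assay compound 2 gives 2100 nM. Compound 3 `COc1cc2c(Oc3ccc(NC(=O)c4cn(-c5ccccc5C)nn4)cc3F)ccnc2cc1OCCCN1CCC(C)CC1` adds a further change to compound 2, methyl in place of hydrogen on a saturated ring carbon, which gave a 1.3-fold higher number from compound 2 to compound 3 (0.11 log units; within the scatter), so that compound 3 gives 2730 nM in this assay. How the core of compound 3 differs from the core of compound 1 is not broken down here.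

Compound 4 `COc1cc2c(Oc3ccc(NC(=O)c4cn(-c5c(C)cccc5C)nn4)cc3F)ccnc2cc1OCCCN1CCC(C)CC1` has not yet been measured. It differs from compound 3 by methyl in place of hydrogen on an aromatic carbon. Among the compounds with values here, this is the same kind of change as the one from compound 1 to compound 2, but not the same: here the entering methyl sits ortho to a large group and also meta to a methyl group, whereas the earlier one sat only ortho to a large group. Because the first such change gave a 10-fold higher number from compound 1 to compound 2 (1.00 log units; beyond the scatter), a further weakening is expected here, estimated as a 2.9-fold higher number from compound 3 to compound 4 (0.47 log units; beyond the scatter), though a second methyl on the same ring need not repeat the full first step. Compound 4 is therefore expected to give about 8000 nM in this assay, with a likely range from 3500 nM to 20000 nM.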

Compound 4, half-maximal inhibitory concentration: 2360 nM
The estimate for compound 4 lay 3.4-fold (0.53 log units) above the measured number; the whole stated range lies above it.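

In this assay, methyl in place of hydrogen on the aromatic ring gave a 1.2-fold lower number from compound 3 to compound 4 (0.06 log units; within the scatter), and this step does not match the earlier one, so the change does not carry over with the same size from one core to the other: the same change on two cores in this assay, a 10-fold higher number (1.00 log units; beyond the scatter) from compound 1 to compound 2 and a 1.2-fold lower number (0.06 log units; within the scatter) from compound 3 to compound 4, 12-fold (1.06 log units) apart, beyond the scatter of two such steps. The two cases are not alike: the first methyl entered a plain phenyl, whereas this one turned 2-methylphenyl into 2,6-dimethylphenyl, and compound 3 also carries a methyl on its saturated ring that compound 1 lacks. The result therefore shows that the size of this step is not fixed in this series, but it does not show whether the methyl already on the aromatic ring, the methyl on the saturated ring, or both account for the gap.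

Still open, going by these compounds, is how 2,6-dimethylphenyl would read on the core of compound 2, which would separate those two differences. Also open, on these data alone, is whether a chlorine or an ethyl group in place of the methyl would give a step like either of these.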